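Ethoxy for Methoxy, Repeated on a Weaker Core

This account rests on a few compounds, and the source may have more. Where it says the series, first, only, none or still open, it means among the compounds named here.

Compound 1 `CNc1nc(-c2cc(OC)c(OC)c(OC)c2)c(-c2ccc(OC)cc2)s1` is the reference point of this small set. In a functional assay on MCF7 cells (Homo sapiens) for antiproliferative activity, read by MTT assay, with a stated time of 72 h (on this read-out higher numbers stand for weaker inhibition and lower numbers for stronger inhibition), compound 1 gives 37.6 nM. Compound 2 `CCOc1ccc(-c2sc(NC)nc2-c2cc(OC)c(OC)c(OC)c2)cc1` carries the change (methyl in place of hydrogen on a saturated chain carbon bound to an oxygen on an aromatic ring), and in this assay compound 2 gives 24.5 nM; the step of a 1.5-fold lower number from compound 1 to compound 2 (0.19 log units; within the scatter) is therefore a small one. Compound 3 `COc1ccc(-c2sc(C)nc2-c2cc(OC)c(OC)c(OC)c2)cc1` differs from compound 1 at the core, the difference being (methyl in place of methylamino on an aromatic carbon). In this assay compound 3 gives 606 nM, and the step of a 16-fold higher number from compound 1 to compound 3 (1.21 log units; beyond the scatter) is the largest movement among the three measured compounds, leaving compound 3 with the highest number of the set and compound 2 with the value furthest from it.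

Compound 4 `CCOc1ccc(-c2sc(C)nc2-c2cc(OC)c(OC)c(OC)c2)cc1` has not yet been measured. It stands to compound 3 exactly as compound 2 stands to compound 1: the change is methyl in place of hydrogen on a saturated chain carbon bound to an oxygen on an aromatic ring, and the place of the change is the same word for word in both pairs, so this is the same change made on a different core. Among the compounds with values here, the only guide to its effect is the one measured step of this kind, a 1.5-fold lower number from compound 1 to compound 2 (0.19 log units; within the scatter), which sits within the scatter. The step from compound 3 to compound 4 is accordingly expected to be small, around a 1.4-fold lower number from compound 3 to compound 4 (0.16 log units; within the scatter), because the matching change gave a 1.5-fold lower number from compound 1 to compound 2 (0.19 log units; within the scatter) in the other pair. Compound 4 is estimated to come in near 420 nM in this assay, with a likely range from 180 nM to 1000 nM.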

Compound 4, half-maximal inhibitory concentration: 42.3 nM
Compound 4: middle estimate off by 9.9-fold (1.00 log units), on the high side, outside the stated range (below it).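

The ethoxy for methoxy change did not carry over from one core to the other with the same size: a 14-fold lower number from compound 3 to compound 4 (1.16 log units; beyond the scatter) in this assay, while on the core of compound 1 the same change stayed within the scatter, and the two steps differ: the same change on two cores in this assay, a 1.5-fold lower number (0.19 log units; within the scatter) from compound 1 to compound 2 and a 14-fold lower number (1.16 log units; beyond the scatter) from compound 3 to compound 4, 9.3-fold (0.97 log units) apart, beyond the scatter of two such steps

The square reads the same way from its other side, where methyl in place of methylamino gives a 1.7-fold higher number from compound 2 to compound 4 (0.24 log units; within the scatter) with ethoxy present, well short of the large step seen with methoxy: the same change on two cores in this assay, a 16-fold higher number (1.21 log units; beyond the scatter) from compound 1 to compound 3 and a 1.7-fold higher number (0.24 log units; within the scatter) from compound 2 to compound 4, 9.3-fold (0.97 log units) apart, beyond the scatter of two such steps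

So the two changes are not independent of each other in this assay, and the size of one step cannot be read across to the other core, yet this single set of four compounds does not show why they interact, nor whether the same holds for any other core or read-out.

The compounds shown leave open whether a longer chain such as propoxy in place of ethoxy would keep the number of compound 4 or move it on either core. They also leave open how an amine without the methyl, or an ethyl group, in place of the methyl of compound 4 would behave with methoxy and with ethoxy.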